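The source may report more compounds than this note shows. Statements on the series, on what has been measured and on what is new or still open speak of the compounds shown alone.

Compound 1 `O=C(C1CCC(F)(F)CC1)N1CC(c2nc(-c3cccc(Cl)c3)no2)C1` is the starting point of this step. In an assay on HEK293 cells for negative allosteric modulation of metabotropic glutamate receptor 5 (Homo sapiens), read by FLIPR (on this read-out lower numbers stand for stronger inhibition and higher numbers for weaker inhibition), compound 1 gives only a limit of the assay, > 10000 nM, so its true value is not known, merely that it lies beyond the highest concentration tested. Two other compounds of the set reach measurable values: compound 2 `O=C(c1ccccc1F)N1CC[C@H]1c1nc(-c2cccc(F)c2)no1` gives 920 nM in this assay, and compound 3 `Cc1ccc(S(=O)(=O)N2CC(c3nc(-c4cccc(Cl)c4)no3)C2)cc1` gives 920 nM, the two sitting within the scatter of each other. The evidence behind compound 1 is the limit of > 10000 nM in this assay, at which 1 of the 3 values shown sits.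

Compound 4 `CC1CCN(C(=O)N2CC(c3nc(-c4cccc(Cl)c4)no3)C2)C1` has not yet been measured in this assay. It differs from compound 1 in one place, (3-methylpyrrolidin-1-yl in place of 4,4-difluorocyclohexyl on a carbonyl carbon). Because compound 1 gives > 10000 nM only as a limit, the step to compound 4 cannot be measured exactly; the expectation is that compound 4 stays weak and the step of an at least 1.2-fold lower number from compound 1 to compound 4 (0.09 log units; that floor lies within the scatter) is expected to be small, if any, beyond the scatter. Compound 4 is estimated to give 8000 nM, with a range from 2000 nM to 30000 nM.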

Compound 4, half-maximal inhibitory concentration: > 10000 nM
Compound 4: no number, only a limit (the forecaster's own chance of this, stated with the estimate: 50%); middle value at least 1.2-fold (0.09 log units) away from the limit.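

In this assay, compound 1 and compound 4 both give only a limit, so no step can be read between them. The compounds shown leave open how 3-methylpyrrolidin-1-yl and 4,4-difluorocyclohexyl on a carbonyl carbon truly compare, as neither true value is known.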